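Swapping a Cyclic Amide for an Open-Chain Carbamate Amide

The source may hold more compounds than are shown below. What is called first, only, known or untested is meant among the compounds shown, and "the series" means these compounds.

Compound 1 `CCOC(=O)C1CCN(C(=O)CN2CN(c3ccccc3)C3(CCN(C(=O)c4ccc(C5CCCCC5)cc4)CC3)C2=O)CC1` gives 900 nM in an assay on HEK293 cells for displacement of a labelled ligand from NPC1-like intracellular cholesterol transporter 1 (Homo sapiens); a higher number here means a weaker inhibitor, a lower number a stronger inhibitor.
Compound 2 `COC(=O)CCNC(=O)CN1CN(c2ccccc2)C2(CCN(C(=O)c3ccc(C4CCCCC4)cc3)CC2)C1=O` gives 12900 nM in this assay.
Compound 3 `O=C(CN1CN(c2ccccc2)C2(CCN(C(=O)c3ccc(C4CCCCC4)cc3)CC2)C1=O)N1CCCCC1` gives 1100 nM in this assay.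

Among these three numbers compound 3 has the second highest. Its nearest neighbour is compound 1, with a 1.2-fold higher number from compound 1 to compound 3 (0.09 log units; within the scatter), a gap within the scatter. Its furthest neighbour is compound 2, with a 12-fold lower number from compound 2 to compound 3 (1.07 log units; beyond the scatter), a large step.

Compound 4 `CC(C)(C)OC(=O)NCCNC(=O)CN1CN(c2ccccc2)C2(CCN(C(=O)c3ccc(C4CCCCC4)cc3)CC2)C1=O` has not yet been measured. It differs from compound 3 in one place: (2-((tert-butoxycarbonyl)amino)ethyl)amino in place of piperidin-1-yl on a carbonyl carbon.

Among the measured compounds shown here, two measured steps bear on this change. Both compare an amide built on a six-membered ring with an amide built on an open chain carrying a hydrogen-bond donor: a 14-fold higher number from compound 1 to compound 2 (1.16 log units; beyond the scatter) and a 12-fold lower number from compound 2 to compound 3 (1.07 log units; beyond the scatter). In both, the open-chain amide gave the much higher number. The change to compound 4 runs in that same direction, from the ring to an open chain, so compound 4 is expected to give a clearly higher number than compound 3, roughly an 8.2-fold higher number from compound 3 to compound 4 (0.91 log units; beyond the scatter). The estimate for compound 4 in this assay is 9000 nM, within a range of 3000 nM to 27000 nM.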

Compound 4, half-maximal inhibitory concentration: 5500 nM
The estimate for compound 4 lay 1.6-fold (0.21 log units) above the measured number; low and high end bracket the measured number.
By their numbers in this assay, from the lowest: compounds 1 and 3 (each within the scatter of the next); then compound 4; then compound 2.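

Compound 4 is a second open-chain amide, and it too gives a higher number than both ring amides in this assay (a 5.0-fold higher number from compound 3 to compound 4 (0.70 log units; beyond the scatter); a 6.1-fold higher number from compound 1 to compound 4 (0.79 log units; beyond the scatter)), so among the compounds shown the ring amides keep the lower numbers, with no compound going against this. What stands at the far end of the open chain also matters, since (tert-butoxycarbonyl)amino in place of methoxycarbonyl lowers the number (a 2.3-fold lower number from compound 2 to compound 4 (0.37 log units; beyond the scatter)), which means the cost of opening the ring is not one fixed amount. That gain does not bring the open chain back to the level of the ring amides, even though this chain is the larger of the two groups exchanged, with 11 heavy atoms against 6 in piperidin-1-yl.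

The compounds shown leave open whether the ring itself or the amide hydrogen of the open chains sets these differences, a question that diethylamino, an open chain with no such hydrogen, could address, while a free amine or a carboxylic acid at the chain end would test that end further. Nothing measured here explains why any of these numbers differ.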